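Shared-core ketones: chain substituent changes and amide hydrolase inhibition

This account rests on a few compounds, and the source may have more. Where it says the series, first, only, none or still open, it means among the compounds named here.

compound 1 `O=C(CCCCCCc1ccccn1)c1ncc(-c2ccccn2)o1`: 120 nM
compound 2 `Nc1ccc(CCCCCCC(=O)c2ncc(-c3ccccn3)o2)cc1`: 3 nM
compound 3 `O=C(CCCCCC(O)c1ccccc1)c1ncc(-c2ccccn2)o1`: 35 nM

In an assay for inhibition of Fatty-acid amide hydrolase 1 (Rattus norvegicus) (on this read-out higher numbers stand for weaker inhibition and lower numbers for stronger inhibition), compound 1 gives the highest of the three numbers; the nearest is reached by a 3.4-fold lower number from compound 1 to compound 3 (0.54 log units; beyond the scatter), the furthest by a 40-fold lower number from compound 1 to compound 2 (1.60 log units; beyond the scatter). Compound 4 `COC(=O)CCCCC(=O)c1ncc(-c2ccccn2)o1` is not yet measured; it differs from compound 1 by methoxycarbonyl in place of 2-(pyridin-2-yl)ethyl on a saturated chain carbon, four bonds along the chain from a carbonyl carbon. Going by the values given here, no measured step exchanges a ring-bearing group for one without a ring. The steps that change the same part of the chain, a 40-fold lower number from compound 1 to compound 2 (1.60 log units; beyond the scatter) and a 12-fold higher number from compound 2 to compound 3 (1.07 log units; beyond the scatter), show that this group moves the read-out strongly while a ring is kept. With no ring entering, a higher number is expected in this assay, a 5.0-fold higher number from compound 1 to compound 4 (0.70 log units; beyond the scatter), beyond the scatter. Compound 4 is therefore estimated at 600 nM, range 150 nM to 3000 nM.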

Compound 4, inhibition constant: 1800 nM
The estimate for compound 4 lay 3.0-fold (0.48 log units) below the measured number; the measured number falls inside the stated range.
By their numbers in this assay, from the lowest: compound 2; then compound 3; then compound 1; then compound 4.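

Methoxycarbonyl in place of 2-(pyridin-2-yl)ethyl is the first change in the series that takes a ring out of the chain, and in this assay it gives a 15-fold higher number from compound 1 to compound 4 (1.18 log units; beyond the scatter). The group that enters also has fewer heavy atoms, so the loss of the ring and the loss of size cannot be told apart from this one step. No measurement on hand bears on the reason for this rise. Open, on these data alone, is whether a carboxylic acid or a primary amide at this place would read like the methyl ester, and whether a longer saturated chain without a ring would restore the lower numbers.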